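The source may report more compounds than this note shows. Statements on the series, on what has been measured and on what is new or still open speak of the compounds shown alone.

Measured so far in a functional assay on CHO cells for antagonist activity at Orexin/Hypocretin receptor type 1 (Homo sapiens), read by FLIPR and calcium flux; on this read-out higher numbers stand for weaker inhibition and lower numbers for stronger inhibition:
compound 1, `Cc1occc1-c1nnc(SCC(=O)Nc2ccc(F)c(Cl)c2)n1Cc1ccco1`: 1000 nM
compound 2, `Cc1ccc(NC(=O)CSc2nnc(-c3ccoc3C)n2Cc2ccco2)cc1`: > 15800 nM, which is a limit of the assay
compound 3, `Cc1occc1-c1nnc(SCC(=O)Nc2ccc(Cl)cc2)n1Cc1ccco1`: 2000 nM

Compound 3 and compound 1 sit within the scatter of each other in this assay, a 2.0-fold higher number from compound 1 to compound 3 (0.30 log units; within the scatter). Compound 2 reaches only the limit, (the limit of > 15800 nM in this assay, at which 1 of the 3 values shown sits). Both steps that touch compound 2 are beyond the scatter: an at least 15-fold higher number from compound 1 to compound 2 (1.19 log units; beyond the scatter), and an at least 7.9-fold lower number from compound 2 to compound 3 (0.89 log units; beyond the scatter). On these three compounds, a halogenated phenyl on the amide-type nitrogen goes with a measurable number, the methylphenyl does not.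

Compound 4, `CC(=O)c1cccc(NC(=O)CSc2nnc(-c3ccoc3C)n2Cc2ccco2)c1`, is not yet measured. It differs from compound 3 by 3-acetylphenyl in place of 4-chlorophenyl on an amide-type nitrogen. Among the compounds with values here, no measured step covers this exact exchange. The closest guide is that the non-halogen aryl of compound 2 went to the limit, an at least 7.9-fold lower number from compound 2 to compound 3 (0.89 log units; beyond the scatter), so for compound 4 a weakening beyond the scatter is expected, a 3.0-fold higher number from compound 3 to compound 4 (0.48 log units; beyond the scatter), though smaller than that seen for compound 2. Compound 4 is therefore estimated at 6000 nM, with a range from 1500 nM to 25000 nM.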

Compound 4, inhibition constant: 3160 nM
The estimate for compound 4 lay 1.9-fold (0.28 log units) above the measured number; the range from low to high includes it.
By their numbers in this assay, from the lowest: compounds 1, 3 and 4 (each within the scatter of the next, the first and the last beyond it). At a limit, above all of these: compound 2.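

In this assay, within the data shown here, a halogen on the aryl group is not needed for a measurable number at this amide-type nitrogen: 3-acetylphenyl in place of 4-chlorophenyl gives a 1.6-fold higher number from compound 3 to compound 4 (0.20 log units; within the scatter), which goes against the halogen reading of the earlier compounds. Against the other two aryl groups the picture splits, with weaker inhibition than 3-chloro-4-fluorophenyl, a 3.2-fold higher number from compound 1 to compound 4 (0.50 log units; beyond the scatter), and stronger inhibition than 4-methylphenyl, an at least 5.0-fold lower number from compound 2 to compound 4 (0.69 log units; beyond the scatter). Compound 2 remains a limit of the assay, not a number: the limit of > 15800 nM in this assay, at which 1 of the 4 values shown sits.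

From the compounds shown here alone, how a phenyl carrying an amine or a carboxylic acid would read at this nitrogen stays open. All the compounds shown change only on the amide-type nitrogen, so they say nothing about the rest of the shared core.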